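Extending the alkoxy chain on a thiomorpholine aryl series

A few compounds are considered here, and "the series" means these few. Any claim that something is new, unique, unknown or untested is made for them only; others in the source may bear on it.

Compound 1 `O=C1CSC(c2ccccc2)CN1` gives > 100000 nM in an assay on isolated protein for inhibition of Amine oxidase [flavin-containing] A (Homo sapiens), read by spectrophotometry; on this read-out higher numbers stand for weaker inhibition and lower numbers for stronger inhibition; this is a limit of this assay, not a number. Compound 2 `CCOc1ccc(C2CNCCS2)cc1` gives 9600 nM.

Compound 2 therefore carries the only actual number among the two results shown, the other being a limit. Compound 3 `CCCOc1ccc(C2CNCCS2)cc1` differs from compound 2 by methyl in place of hydrogen on a saturated chain carbon, two bonds along the chain from an oxygen on an aromatic ring. Among the measured compounds shown here, no measured pair shows a step of this kind, so the size of the change is open; a small shift, none beyond the usual scatter, is the expectation. The step from compound 2 to compound 3 is expected to be a 1.4-fold lower number from compound 2 to compound 3 (0.14 log units; within the scatter). Compound 3 is estimated at 7000 nM, within 2500 nM to 20000 nM.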

Compound 3, inhibition constant: 6620 nM
For compound 3 the middle estimate is 1.1-fold (0.02 log units) above the measured one; the range from low to high includes it.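

Going from ethoxy to propoxy gives a 1.5-fold lower number from compound 2 to compound 3 (0.16 log units; within the scatter) in this assay and so shows that this position takes the added methyl with no change that stands clear of the scatter. Among the compounds shown here, this is the only step read at this position, so it sets no trend along the chain. Nothing measured here gives a cause for this result. On these data alone, what a longer chain such as butoxy would do stays open, as does the effect of an amine or a carboxylic acid in place of the propoxy.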